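The source may report more compounds than this note shows. Statements on the series, on what has been measured and on what is new or still open speak of the compounds shown alone.

Measured compounds:
compound 1 `CCS(=O)(=O)c1ccc(OCC[C@@H]2C[C@@H]2C2CCN(c3nc(C(C)C)no3)CC2)c(F)c1` – 1.7 nM
compound 2 `CCS(=O)(=O)c1ccc(COC[C@@H]2C[C@@H]2C2CCN(c3nc(C(C)C)no3)CC2)c(F)c1` – 0.8 nM

Two compounds have so far been characterised in a functional assay on CHO cells for agonist activity at Glucose-dependent insulinotropic receptor (Homo sapiens), read by cAMP accumulation; on this read-out lower numbers stand for an effect already at smaller amounts and higher numbers for an effect only at larger amounts of compound. Compound 1 gives 1.7 nM in this assay, while compound 2 gives 0.8 nM. Compound 2 thus stands lowest of the two numbers; the gap to compound 1 lies beyond the usual scatter of such measurements, so compound 2 is the more potent of the pair on this read-out.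

Compound 3 `CC(C)c1noc(N2CCC([C@H]3C[C@H]3COCc3ccc(S(C)(=O)=O)cc3F)CC2)n1` has not yet been measured in this assay. It differs from compound 2 in one place only: hydrogen in place of methyl on a saturated chain carbon bound to a sulfonyl sulfur – hydrogen in place of methyl on a saturated chain carbon bound to a sulfonyl sulfur, which read one bond further out is ethylsulfonyl to methylsulfonyl. Among the compounds with values here, no measured pair in this set shows this change, so its effect can only be expected, not read off. A change this small, remote from the rest of the molecule, is expected to leave the number about where compound 2 stands, with at most a slight rise.

Compound 3 is therefore estimated at 1.2 nM in this assay, within a range of 0.5 nM to 3 nM. This estimate corresponds to an expected step of a 1.5-fold higher number from compound 2 to compound 3 (0.18 log units; within the scatter), which is expected to remain within the scatter.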

Compound 3, half-maximal effective concentration: 4.2 nM
The estimate for compound 3 lay 3.5-fold (0.54 log units) below the measured number; the measured number lies above the stated range.
By their numbers in this assay, from the lowest: compound 2; then compound 1; then compound 3.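

In this assay, cutting ethylsulfonyl back to methylsulfonyl gives a 5.3-fold higher number from compound 2 to compound 3 (0.72 log units; beyond the scatter), so this position is not indifferent to the loss of a single carbon, as the two earlier compounds could not show because neither differed from the other at this place. Within the data shown here, on the one pair available, the ethyl group on the sulfonyl goes with the lower number and the methyl group with the higher one, and the step is large enough to stand clear of the usual variation between repeated measurements. No accompanying measurement bears on why the removal of this methyl moves the number, and the data offer no explanation for it.

The compounds shown leave open whether the trend continues along the chain, that is, whether a longer chain such as propylsulfonyl or a branched one such as isopropylsulfonyl would lower the number further or raise it again. They also leave open whether the same change from ethyl to methyl would produce a step of similar size on compound 1, which carries ethylsulfonyl too.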